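Compound 4: Anilino-Type Change at the Shared Core

This account rests on a few compounds, and the source may have more. Where it says the series, first, only, none or still open, it means among the compounds named here.

Compound 1, `COc1cc(C(=O)c2sc3ccccc3c2-c2ccc(F)cc2)cc(OC)c1OC`: 2100 nM
Compound 2, `COc1cc(C(=O)c2sc3ccccc3c2-c2ccc(Cl)cc2)cc(OC)c1OC`: 4200 nM
Compound 3, `COc1cc(C(=O)c2sc3ccccc3c2Nc2ccccc2)cc(OC)c1OC`: 2300 nM

In a functional assay on K562 cells (Homo sapiens) for antiproliferative activity, read by MTT assay, with a stated time of 72 h (a lower number here means a stronger inhibitor, a higher number a weaker inhibitor), compound 1 gives the lowest of the three numbers, though neither gap is beyond the scatter: the nearest step is a 1.1-fold higher number from compound 1 to compound 3 (0.04 log units; within the scatter) and the furthest is a 2.0-fold higher number from compound 1 to compound 2 (0.30 log units; within the scatter). Compound 4, `COc1cc(C(=O)c2sc3ccccc3c2Nc2ccc(C)cc2)cc(OC)c1OC`, differs from compound 1 by (4-methylphenyl)amino in place of 4-fluorophenyl on an aromatic carbon. The step that bears on this is the one in which anilino entered for 4-fluorophenyl, moving the number by only a 1.1-fold higher number from compound 1 to compound 3 (0.04 log units; within the scatter); the related step of a 1.8-fold lower number from compound 2 to compound 3 (0.26 log units; within the scatter) also stayed within the scatter. The step to compound 4 is therefore expected to stay within the scatter, an estimated 1.2-fold higher number from compound 1 to compound 4 (0.08 log units; within the scatter). For compound 4 the estimated value is 2500 nM, with a range from 1000 nM to 6500 nM.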

Compound 4, half-maximal inhibitory concentration: 1600 nM
Beside the measured number, compound 4's estimate is 1.6-fold (0.19 log units) above it; measured number inside the range.
By their numbers in this assay, from the lowest: compounds 4, 1, 3 and 2 (each within the scatter of the next, the first and the last beyond it).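

In this assay, methyl in place of hydrogen on the anilino ring stays within the scatter (a 1.4-fold lower number from compound 3 to compound 4 (0.16 log units; within the scatter)), as does the full exchange of 4-fluorophenyl for (4-methylphenyl)amino (a 1.3-fold lower number from compound 1 to compound 4 (0.12 log units; within the scatter)). The exchange of 4-chlorophenyl for (4-methylphenyl)amino is the only step among these compounds to pass beyond the scatter, and only modestly (a 2.6-fold lower number from compound 2 to compound 4 (0.42 log units; beyond the scatter)). Nothing measured here accounts for that step.

The compounds shown leave open whether an amine, a carboxylic acid or a longer chain in place of that methyl would move the number beyond the scatter.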